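This account rests on a few compounds, and the source may have more. Where it says the series, first, only, none or still open, it means among the compounds named here.

Compound 1 `CCn1c(C(=O)N(C)c2ccccc2)ccc1C(CC)(CC)c1ccc(OCC(=O)C(C)(C)C)c(C)c1` gives in an assay on HL-60 cells for agonist activity at vitamin D3 receptor (Homo sapiens), read by microscopy, with a stated time of 96 h (a lower number here means that less compound is needed, a higher number that more compound is needed for the effect), a value of 18500 nM. Compound 2 `CCOC(=O)CC(C)OC(=O)c1ccc(C(CC)(CC)c2ccc(OCC(=O)C(C)(C)C)c(C)c2)n1CC` is reported only at a limit of the assay, > 50000 nM. Compound 3 `CCn1c(C(=O)N(C)c2ccccc2)ccc1C(CC)(CC)c1ccc(OCC(O)C(C)(C)C)c(C)c1` gives 6400 nM in this assay. Among the two numbers shown, compound 3 stands lowest; the number fell a 2.9-fold lower number from compound 1 to compound 3 (0.46 log units; beyond the scatter) when 1-hydroxy-2,2-dimethylpropyl replaced (tert-butyl)carbonyl on the saturated chain carbon bound to the aromatic oxygen. Compound 4 `CCn1c(C(=O)OCc2ccc(F)cc2)ccc1C(CC)(CC)c1ccc(OCC(O)C(C)(C)C)c(C)c1` has not yet been measured. It differs from compound 3 at the carbonyl carbon: (4-fluorobenzyl)oxy in place of methyl(phenyl)amino on a carbonyl carbon. Within the data shown here, one measured step bears on a change at that same carbonyl carbon, namely an at least 2.7-fold higher number from compound 1 to compound 2 (0.43 log units; beyond the scatter), in which the methyl(phenyl)amino group was exchanged for a group with no ring. That step ended with compound 2 at a limit, (the limit of > 50000 nM in this assay, at which 1 of the 3 values shown sits). The group entering compound 4 keeps one six-membered aromatic ring of carbon only, so a step in the same direction, toward a higher number, but of a more modest size is expected. Compound 4 is therefore expected to give about 16000 nM in this assay, somewhere between 5000 nM and 50000 nM. This expectation corresponds to a step of a 2.5-fold higher number from compound 3 to compound 4 (0.40 log units; beyond the scatter).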

Compound 4, half-maximal effective concentration: > 50000 nM
Compound 4 gave a limit, no number (the forecaster's own chance of this, stated with the estimate: 25%); middle value at least 3.1-fold (0.49 log units) away from the limit.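

The change from methyl(phenyl)amino to (4-fluorobenzyl)oxy on this carbonyl carbon gives an at least 7.8-fold higher number from compound 3 to compound 4 (0.89 log units; beyond the scatter), so an entering group that keeps a six-membered aromatic ring of carbon only still does not hold the number near that of compound 3. Among these compounds, until now the only exchange at this position had been measured with the (tert-butyl)carbonyl group present and with a group that has no ring; this step shows that the exchange also costs activity with the 1-hydroxy-2,2-dimethylpropyl group in place, and with a ring retained. In this assay compound 4 is reported only at a limit of the assay, the same limit as for compound 2: the limit of > 50000 nM in this assay, at which 2 of the 4 values shown sit.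

The true size of the step stays unknown, as the value of compound 4 is a limit and not a number, and the compounds shown do not separate the role of the linking oxygen from that of the 4-fluorobenzyl group. A (4-fluorobenzyl)amino group or a benzyl(methyl)amino group on the same carbonyl carbon would be needed to tell these two apart.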